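The source may hold more compounds than are shown below. What is called first, only, known or untested is meant among the compounds shown, and "the series" means these compounds.

Of the compounds shown here, two have been measured so far in a physicochemical assay for lipophilicity, read by HPLC, at pH 7.4 (on this read-out lower numbers stand for lower lipophilicity and higher numbers for higher lipophilicity), and their numbers sit well apart. Compound 2 `CCC/N=C1\S/C(=C\c2ccc(O)c(Cl)c2)C(=O)N1c1ccccc1O` gives 2.7 in this test, the lower of the two numbers, while compound 1 `CCC/N=C1\S/C(=C\c2ccc(O)c(C(C)C)c2)C(=O)N1c1ccccc1C` gives 4.3 on the same scale, a gap beyond the usual scatter. The next compound to be measured is compound 3 `CCC/N=C1\S/C(=C\c2ccc(O)c(Cl)c2)C(=O)N1c1ccccc1C` which keeps all of compound 2 except for one group. It has methyl in place of hydroxy on an aromatic carbon and this turns 2-hydroxyphenyl into 2-methylphenyl. Among the measured compounds shown here, no two measured compounds differ in only one place, so no measured step shows the size of this change directly. The nearest guide is compound 1 at 4.3. Compound 1 carries 2-methylphenyl too, although it also differs from compound 3 elsewhere. An upward step beyond the scatter is expected in this assay with a number 1.10 log units higher from compound 2 to compound 3 (beyond the scatter) as its estimated size. Compound 3 is estimated at 3.8 with an expected range of 3.4 to 4.2 on this scale.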

Compound 3, distribution coefficient: 3.8
For compound 3 middle estimate and measured number coincide at the digits printed; the range from low to high includes it.
By their numbers in this assay, from the lowest: compound 2; then compound 3; then compound 1.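

Among the compounds shown here, compound 3 gives the first pairs of compounds that differ in one place only, so the size of a single change in this assay can now be read directly. Turning 2-hydroxyphenyl into 2-methylphenyl replaces a group counted as a hydrogen-bond donor and acceptor with one counted as neither, and it gives a number 1.10 log units higher from compound 2 to compound 3 (beyond the scatter), a large step; in the other changed place, chloro in place of isopropyl on an aromatic carbon gives a number 0.50 log units lower from compound 1 to compound 3 (beyond the scatter), a modest step. So each of these two places on the shared core can move this number beyond the scatter, but nothing measured here accounts for the size or direction of either step.

Only one replacement for hydroxy is shown at this place, so it remains open where a methoxy group, a fluorine atom or an amine would fall relative to compound 2 and compound 3. On these data alone, it is also open whether the change from hydroxy to methyl would keep its size with isopropyl in place of chloro, since each step here comes from a single pair.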